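This account rests on a few compounds, and the source may have more. Where it says the series, first, only, none or still open, it means among the compounds named here.

Measured compounds:
- compound 1 `COc1ccc(Nc2cc(C)oc(=O)c2)cc1`: > 30 uM
- compound 2 `Cc1ccc(Nc2cc(-c3ccccc3)oc(=O)c2)cc1`: 0.073 uM

In a functional assay on DU-145 cells (Homo sapiens) for cytotoxicity, read by MTT assay, with a stated time of 72 h (on this read-out higher numbers stand for an effect only at larger amounts of compound and lower numbers for an effect already at smaller amounts), compound 1 reaches only the limit of the assay, > 30 uM, and no number is known for it; the record shows (the limit of > 30 uM in this assay, at which 1 of the 2 values shown sits). Compound 2 gives 0.073 uM in this assay. Among the compounds with values here, the two compounds differ in more than one place, so their values show only that compound 1 sits at the limit while compound 2 gives a low number.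

Compound 3 `COc1ccc(Nc2cc(C3CCCC3)oc(=O)c2)cc1` differs from compound 1 by one change, cyclopentyl in place of methyl on an aromatic carbon, next to the ring oxygen. Within the data shown here, no measured step covers this change. Compound 3 is expected to move away from the limit seen for compound 1, with an estimated step of an at least 10-fold lower number from compound 1 to compound 3 (1.00 log units; beyond the scatter) in this assay. Compound 3 is estimated at 3 uM, within a range from 0.3 uM to 30 uM.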

Compound 3, concentration for half-maximal effect: 5.42 uM
Compound 3: the middle estimate sits 1.8-fold (0.26 log units) below what was measured, and the stated range covers the measured number.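

With compound 3, this place next to the ring oxygen gets its first reading from a change in one place only: in this assay, cyclopentyl in place of methyl on an aromatic carbon gives an at least 5.5-fold lower number from compound 1 to compound 3 (0.74 log units; beyond the scatter). The earlier compounds shown here could not show this, as compound 1 and compound 2 differ in more than one place. Going by these compounds, the true size of the step stays unknown because compound 1 sits at a limit and not at a number: the limit of > 30 uM in this assay, at which 1 of the 3 values shown sits.

The compounds shown leave open whether the ring itself matters or the added carbons alone, which an open chain such as n-pentyl or a smaller ring such as cyclopropyl at this place could separate. On these data alone, how an amine or a carboxylic acid on this carbon would read is also open.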